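Swapping a Cyclohexyl Amide for a Fluorobenzyl Amide

The source may report more compounds than this note shows. Statements on the series, on what has been measured and on what is new or still open speak of the compounds shown alone.

Measured so far in an assay on isolated protein for binding affinity to growth hormone secretagogue receptor type 1 (Homo sapiens); on this read-out higher numbers stand for weaker inhibition and lower numbers for stronger inhibition:
Compound 1, `CCN(CC)CCCN(C(=O)c1ccc(-c2ccccc2)[nH]1)C(C(=O)NC1CCCCC1)c1ccc(F)cc1`, gives 1290 nM.
Compound 2, `CCN(CC)CCN(C(=O)c1ccc(-c2ccccc2)[nH]1)C(C(=O)NC1CCCCC1)c1ccc(F)cc1`, gives 1370 nM.
Compound 3, `CCN(CC)CCCN(C(=O)CCN1CCCc2ccccc21)C(C(=O)NC1CCCCC1)c1ccc(F)cc1`, gives 2030 nM.

Compound 1 has the lowest number of the three, but the other two sit close to it: a 1.1-fold higher number from compound 1 to compound 2 (0.03 log units; within the scatter) and a 1.6-fold higher number from compound 1 to compound 3 (0.20 log units; within the scatter) both lie within the scatter, so on this read-out the three compounds cannot be told apart. Compound 4, `CCN(CC)CCCN(C(=O)c1ccc(-c2ccccc2)[nH]1)C(C(=O)NCc1ccc(F)cc1)c1ccc(F)cc1`, differs from compound 1 in one place: 4-fluorobenzyl in place of cyclohexyl on an amide-type nitrogen. Neither measured step touches this amide-type nitrogen. The step to compound 2 alters the chain that carries the diethylamino group, and the step to compound 3 exchanges the group on the carbonyl carbon; both changes left the number where it was. Going by these compounds, the shared core has so far tolerated changes at two different places without moving beyond the scatter, so the change at the carbamoyl nitrogen is expected to behave alike, with no step beyond the scatter in this assay, while the direction remains open. Compound 4 is therefore estimated at 1500 nM, with a range from 500 nM to 4500 nM, which means an expected step of a 1.2-fold higher number from compound 1 to compound 4 (0.07 log units; within the scatter).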

Compound 4, inhibition constant: 1150 nM
Estimate against measurement, compound 4: 1.3-fold (0.12 log units) above, within the range that was stated.
By their numbers in this assay, from the lowest: compounds 4, 1, 2 and 3 (each within the scatter of the next).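

In this assay, putting 4-fluorobenzyl in place of cyclohexyl on the amide-type nitrogen gives a 1.1-fold lower number from compound 1 to compound 4 (0.05 log units; within the scatter), so this is a third place on the shared core where a change has not moved the number beyond the scatter. The step replaces a non-aromatic ring of carbon only with an aromatic one and also brings in a fluorine, and neither change shifts the reading measurably on this evidence. The two changes arrive together, so this single step cannot separate them, and no supporting measurement is available to explain the result.

The compounds shown leave open whether plain benzyl, without the fluorine, would also stay within the scatter. They also leave open whether a group on this nitrogen carrying an amine or a carboxylic acid would move the number beyond it.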